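The source may hold more compounds than are shown below. What is called first, only, known or untested is meant among the compounds shown, and "the series" means these compounds.

Compound 1 `CS(=O)(=O)c1ccc(Nc2nccc(Nc3nc4ccc(F)cc4s3)n2)cc1`: 1940 nM in a functional assay on PC-3 cells (Homo sapiens) for antiproliferative activity, read by MTT assay, with a stated time of 48 h; on this read-out lower numbers stand for stronger inhibition and higher numbers for weaker inhibition.
Compound 2 `Cc1cnc(Nc2ccc(S(C)(=O)=O)cc2)nc1Nc1nc2ccc(F)cc2s1`: in this assay compound 2 reaches only a limit, > 50000 nM.

Among the compounds with values here, compound 1 carries the only real number in this assay; the value of compound 2 is a limit, (the limit of > 50000 nM in this assay, at which 1 of the 2 values shown sits). Within the data shown here, the single measured step, an at least 25-fold higher number from compound 1 to compound 2 (1.41 log units; beyond the scatter), concerns a methyl on an aromatic carbon and does not touch the sulfonyl group. Among the measured compounds shown here, compound 3 `NS(=O)(=O)c1ccc(Nc2nccc(Nc3nc4ccc(F)cc4s3)n2)cc1` differs from compound 1 by amino in place of methyl on a sulfonyl sulfur, methylsulfonyl to sulfamoyl, and no measured step covers that change. In this assay the change is expected to give a 1.0-fold higher number from compound 1 to compound 3 (0.01 log units; within the scatter). Compound 3 is estimated at 2000 nM, with a range from 700 nM to 6000 nM.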

Compound 3, half-maximal inhibitory concentration: 920 nM
Compound 3: middle estimate off by 2.2-fold (0.34 log units), on the high side; the measured number falls inside the stated range.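

In this assay, within the data shown here, amino in place of methyl on a sulfonyl sulfur gives a 2.1-fold lower number from compound 1 to compound 3 (0.32 log units; beyond the scatter), the first reading at this position. The sulfonyl sulfur therefore accepts methylsulfonyl to sulfamoyl with a modest gain, and the added hydrogen-bond donor comes with no loss in this read-out. Nothing shown gives a cause for this step.

Open, on these data alone, is how a methylamino, a dimethylamino or an ethyl on the sulfonyl sulfur would read. Also open, as far as these compounds go, is whether a carboxylic acid in place of the whole methylsulfonyl would keep the number.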